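Urea Tail Swap: Dichlorophenyl to Trifluoromethylphenyl

This account rests on a few compounds, and the source may have more. Where it says the series, first, only, none or still open, it means among the compounds named here.

Measured compounds:
- compound 1, `COc1cc(Cl)cc(-c2nn(-c3cccc(NC(=O)Nc4cc(C(F)(F)F)cc(C(F)(F)F)c4)c3)cc2-c2ccncc2)c1`: 96%
- compound 2, `COc1cc(Cl)cc(-c2nn(-c3cccc(NC(=O)Nc4ccc(Cl)c(Cl)c4)c3)cc2-c2ccncc2)c1`: 97%

In a functional assay on SN12C cells (Homo sapiens) for inhibition, read by sulforhodamine B assay, with a stated time of 48 h, tested at 0.01 uM (a lower number here means a stronger effect, a higher number a weaker effect of the compound at the concentration tested), compound 1 gives 96%, and in the same test compound 2 gives 97%. These two numbers lie within the usual scatter of each other, so neither compound can be called the weaker or the stronger of the pair; both show only a small effect at the concentration used. Compound 2 carries the 3,4-dichlorophenyl group on its urea, and compound 1 carries a bis(trifluoromethyl)phenyl group, yet the read-outs are essentially the same.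

Compound 3, `COc1cc(Cl)cc(-c2nn(-c3cccc(NC(=O)Nc4cccc(C(F)(F)F)c4)c3)cc2-c2ccncc2)c1`, has not been measured. It differs from compound 2 in one place: 3-(trifluoromethyl)phenyl in place of 3,4-dichlorophenyl on an amide-type nitrogen. Since the two measured compounds, with quite different groups at this same position, gave nearly identical numbers, no step beyond the scatter is expected here. The estimated step of a number 1 percentage points lower from compound 2 to compound 3 (within the scatter) is expected to be small. Compound 3 is therefore expected to give about 96%, within a range from 88% to 102%.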

Compound 3, a percentage reported as activity, at one concentration (the size of the read-out at that concentration, not a potency): 101%
Compound 3: the middle estimate sits 5 percentage points below what was measured; measured number inside the range.
By their numbers in this assay, from the lowest: compounds 1, 2 and 3 (each within the scatter of the next).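

In this assay, 3-(trifluoromethyl)phenyl in place of 3,4-dichlorophenyl on the amide-type nitrogen gives a number 4 percentage points higher from compound 2 to compound 3 (within the scatter), so this swap produces no readable change. Compound 3 also allows a second one-place comparison: hydrogen in place of trifluoromethyl on an aromatic carbon gives a number 5 percentage points higher from compound 1 to compound 3 (within the scatter), so taking away one of the two trifluoromethyl groups produces no readable change either. Across these two single changes, the aromatic group on this nitrogen can be altered in its substituents, including their number, without the read-out leaving the scatter at this one low concentration.

These compounds all carry a substituted phenyl group here, so they leave open whether a different kind of group, such as a phenyl ring bearing a carboxylic acid or an amine, would shift the number, and whether the three tail groups would separate at a higher concentration. Nothing at hand speaks to what lies behind these read-outs.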